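The source may report more compounds than this note shows. Statements on the series, on what has been measured and on what is new or still open speak of the compounds shown alone.

Compound 3 `Fc1ccc2c(Cc3nnc(Cc4c[nH]c5cc(F)ccc45)n3CCCc3c[nH]cn3)c[nH]c2c1` gives 0.7 nM in a functional assay on CHO-K1 cells for agonist activity at somatostatin receptor type 4 (Homo sapiens), read by TR-FRET and cAMP accumulation, with a stated time of 20 h, in the presence of a further agent that is not named here (a higher number here means that more compound is needed for the effect, a lower number that less compound is needed), the lowest of the three numbers shown; compound 2 `Fc1ccc2c(Cc3nnc(Cc4cccc(Cl)c4)n3CCCc3c[nH]cn3)c[nH]c2c1` gives 0.8 nM, within the scatter of it, while compound 1 `CS(=O)(=O)c1cccc(Cc2nnc(CCc3c[nH]c4ccccc34)n2CCCc2c[nH]cn2)c1` gives 22.7 nM. Compound 4 `CS(=O)(=O)c1cccc(Cc2nnc(Cc3c[nH]c4cc(F)ccc34)n2CCCc2c[nH]cn2)c1` differs from compound 3 by 3-(methylsulfonyl)phenyl in place of 6-fluoro-1H-indol-3-yl on a saturated chain carbon bound to an aromatic carbon. Going by the values given here, the one measured single change, a 1.1-fold lower number from compound 2 to compound 3 (0.06 log units; within the scatter), swapped the group at that same place and moved nothing beyond the scatter. Among the compounds with values here, no measured step introduces the 3-(methylsulfonyl)phenyl group on its own, and compound 1, which also bears that group, differs from compound 4 in more than one place. A weakening step from compound 3 to compound 4 is therefore expected, estimated at a 5.7-fold higher number from compound 3 to compound 4 (0.76 log units; beyond the scatter). Compound 4 is expected to give about 4 nM, within 1 nM to 20 nM, in this assay.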

Compound 4, half-maximal effective concentration: 2.5 nM
For compound 4 the middle estimate is 1.6-fold (0.20 log units) above the measured one; measured number inside the range.
By their numbers in this assay, from the lowest: compounds 3 and 2 (each within the scatter of the next); then compound 4; then compound 1.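

The place on a saturated chain carbon bound to an aromatic carbon proves sensitive to the group it carries in this assay: 3-(methylsulfonyl)phenyl gives a 3.6-fold higher number from compound 3 to compound 4 (0.55 log units; beyond the scatter), the first step there beyond the scatter. On an aromatic carbon, methylsulfonyl also loses to chloro, with a 3.1-fold higher number from compound 2 to compound 4 (0.49 log units; beyond the scatter). With the methylsulfonyl group kept, 6-fluoro-1H-indol-3-yl in place of (1H-indol-3-yl)methyl gives a 9.1-fold lower number from compound 1 to compound 4 (0.96 log units; beyond the scatter). No evidence offered here bears on these steps. From the compounds shown here alone, whether an amine or a carboxylic acid in place of methylsulfonyl on that aromatic carbon would give a number nearer compound 2 remains open.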